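Chloro Removal on a Sulfonamide Amide Series with Limits Only

A few compounds are considered here, and "the series" means these few. Any claim that something is new, unique, unknown or untested is made for them only; others in the source may bear on it.

Compound 1, `COc1ccc(Cl)cc1N(CC(=O)Nc1ccccc1)S(=O)(=O)c1ccccc1`, gives in a functional assay on SH-SY5Y cells (Homo sapiens), read by MTT assay, with a stated time of 24 h (a higher number here means that more compound is needed for the effect, a lower number that less compound is needed), only a limit, > 20000 nM. Compound 2, `COc1ccc(Cl)cc1N(CC(=O)Nc1ccc(Cl)cc1)S(=O)(=O)c1ccccc1`, gives in this assay only a limit, > 20000 nM. Compound 3, `COc1ccc(Cl)cc1NC(=O)CN(c1cc(Cl)ccc1OC)S(=O)(=O)c1ccccc1`, gives in this assay only a limit, > 20000 nM.

All three measured values sit at the same limit of this assay, (the limit of > 20000 nM in this assay, at which 3 of the 3 values shown sit), so none of them is a number, and every step between them is unreadable. From compound 2 to compound 1 the change is hydrogen in place of chloro on an aromatic carbon, and the step is a step that the two limits leave unreadable from compound 2 to compound 1. Compound 2 and compound 3 differ in their cores by 5-chloro-2-methoxyphenyl in place of 4-chlorophenyl on an amide-type nitrogen, and the step is a step that the two limits leave unreadable from compound 2 to compound 3.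

Compound 4, `COc1ccccc1NC(=O)CN(c1cc(Cl)ccc1OC)S(=O)(=O)c1ccccc1`, is not yet measured in this assay. It differs from compound 3 by hydrogen in place of chloro on an aromatic carbon. For the measured compounds named here, this is the same kind of change as the one from compound 2 to compound 1, but the surroundings differ: in compound 2 the chloro sits para to a large group, whereas in compound 3 it sits meta to a large group and para to a methoxy group.

Because compound 3 shows only the limit > 20000 nM, and compound 1 and compound 2 also sit at that limit, compound 4 is expected to give a step that the limit leaves unreadable from compound 3 to compound 4 in this assay, most likely again unreadable. The estimated value for compound 4 is 35000 nM, expected to lie between 10000 nM and 150000 nM.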

Compound 4, half-maximal effective concentration: 15500 nM
Compound 4: the middle estimate sits 2.3-fold (0.35 log units) above what was measured, and the stated range covers the measured number.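

Replacing chloro by hydrogen on the 5-chloro-2-methoxyphenyl group gives an at least 1.2-fold lower number from compound 3 to compound 4 (0.11 log units; that floor lies within the scatter), and the two other readable comparisons are an at least 1.2-fold lower number from compound 2 to compound 4 (0.11 log units; that floor lies within the scatter) and an at least 1.2-fold lower number from compound 1 to compound 4 (0.11 log units; that floor lies within the scatter). Going by these compounds, each of these is only a floor set by a limit on one side, so the real size of each step stays unknown, and none of them shows a difference beyond the usual scatter. The same replacement of chloro by hydrogen also links compound 2 and compound 1, but that step and the other steps among compounds 1, 2 and 3 cannot be read, so this series does not show whether the change carries from one core to another, because both ends of that pair are limits: the limit of > 20000 nM in this assay, at which 3 of the 4 values shown sit.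

The compounds shown leave open how the number would respond if an amine, a carboxylic acid or a longer chain stood in place of the methoxy group on the 2-methoxyphenyl ring of compound 4. On these data alone, compound 4 is the only one here with a measured number, 15500 nM, and it remains open whether any close relative of it would give a number clearly lower in this assay.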